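The source may hold more compounds than are shown below. What is called first, only, known or untested is meant among the compounds shown, and "the series" means these compounds.

Measured in a functional assay on HCT-116 cells (Homo sapiens) for inhibition, read by MTT assay, with a stated time of 48 h; a higher number here means a weaker inhibitor, a lower number a stronger inhibitor:
- compound 1 `COc1ccc(CNc2cc(OC)c(OC)c(OC)c2)cc1C`: 60900 nM
- compound 2 `COc1ccc(CNc2cc(OC)c(OC)c(OC)c2)cc1`: 18400 nM

Compound 2 has the lower number of the two, and the gap to compound 1 lies beyond the scatter. Compound 3 `COc1ccc(CNc2cc(OC)c(OC)c(OC)c2)cc1N` differs from compound 2 in one place: amino in place of hydrogen on an aromatic carbon. The new amino group stands ortho to a methoxy group.

Among the compounds with values here, one measured step bears on this carbon: a 3.3-fold lower number from compound 1 to compound 2 (0.52 log units; beyond the scatter), with hydrogen in place of methyl. That step is modest, yet it shows that a change at this carbon can move the number. Within the data shown here, no measured compound carries amino, so the direction is not fixed by the data. A modest step towards a lower number in this assay is a tentative expectation. The expected step is a 2.6-fold lower number from compound 2 to compound 3 (0.42 log units; beyond the scatter). The estimate for compound 3 is 7000 nM, expected to fall between 1000 nM and 40000 nM.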

Compound 3, half-maximal inhibitory concentration: 8270 nM
Beside the measured number, compound 3's estimate is 1.2-fold (0.07 log units) below it, and the stated range covers the measured number.
By their numbers in this assay, from the lowest: compound 3; then compound 2; then compound 1.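

In this assay, this carbon has now carried three different groups, and the result shows that putting a group there does not have to raise the number: methyl raised it, whereas amino gives a 2.2-fold lower number from compound 2 to compound 3 (0.35 log units; beyond the scatter). The widest gap at this carbon is between the two groups themselves, a 7.4-fold lower number from compound 1 to compound 3 (0.87 log units; beyond the scatter), so the outcome depends on which group sits there and not only on whether the carbon is substituted. Nothing available here explains why amino and methyl differ in this way. From the compounds shown here alone, what a hydroxyl group, an acetamide or a dimethylamino group would do at this carbon remains open. Going by these compounds, it is also open whether amino would give a similar step on a different carbon of the same aromatic ring.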